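From Nitro to Methoxycarbonyl on a Shared Core

A few compounds are considered here, and "the series" means these few. Any claim that something is new, unique, unknown or untested is made for them only; others in the source may bear on it.

Compound 1 `Cc1nn(C)c(Oc2ccc(Cl)cc2)c1/C=N/OCc1ccc(C(F)(F)F)cc1` and compound 2 `Cc1nn(C)c(Oc2ccc(Cl)cc2)c1/C=N/OCc1ccc([N+](=O)[O-])cc1` differ at one aromatic carbon only. In a functional assay on HepG2 cells (Homo sapiens) for antiproliferative activity, tested at 1 uM (a lower number here means less inhibition, a higher number more inhibition at the concentration tested (going by the name of the read-out)), compound 1 gives 20.6% and compound 2 gives 18.4%, a step of a number 2.2 percentage points lower from compound 1 to compound 2 (within the scatter). Of the two numbers shown, compound 2 gives the lower one, yet its gap to compound 1 lies within the scatter. Compound 3 `COC(=O)c1ccc(CO/N=C/c2c(C)nn(C)c2Oc2ccc(Cl)cc2)cc1` carries methoxycarbonyl in place of nitro on an aromatic carbon. Among the compounds with values here, the single measured step swapped a group on that same aromatic carbon and stayed within the scatter, so compound 3 is expected to show a step of a number 0.6 percentage points higher from compound 2 to compound 3 (within the scatter) in this assay. Compound 3 is therefore estimated at 19%, within 9% to 30%.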

Compound 3, a percentage reported as inhibition, at one concentration (the size of the read-out at that concentration, not a potency): 20.3%
Estimate against measurement, compound 3: 1.3 percentage points below; low and high end bracket the measured number.
By their numbers in this assay, from the lowest: compounds 2, 3 and 1 (each within the scatter of the next).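

In this assay, methoxycarbonyl on this aromatic carbon gives a number 1.9 percentage points higher from compound 2 to compound 3 (within the scatter), and a number 0.3 percentage points lower from compound 1 to compound 3 (within the scatter). Three different groups at this place, para to a large group, thus sit within the scatter of one another, and the entering methoxycarbonyl has four heavy atoms where nitro has three. No measurement at hand gives a reason for this flat result.

As far as these compounds go, whether an amine, a carboxylic acid or a longer chain on this carbon would move the number beyond the scatter stays open, as does the effect of any change elsewhere on the shared core.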